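Bromine on the indole ring of a cyanodienone series

This account rests on a few compounds, and the source may have more. Where it says the series, first, only, none or still open, it means among the compounds named here.

Of the compounds shown here, three of one shared core have been measured in a functional assay on MCF7 cells (Homo sapiens) for cytotoxicity, read by sulforhodamine B assay, with a stated time of 48 h; on this read-out higher numbers stand for weaker inhibition of growth and lower numbers for stronger inhibition of growth. Compound 1 `COc1ccc(/C(Cl)=C/C=C(\C#N)C(=O)c2c[nH]c3ccc(Br)cc23)cc1` gives 80300 nM. Compound 2 `COc1cc(/C(Cl)=C/C=C(\C#N)C(=O)c2c[nH]c3ccc(Br)cc23)cc(OC)c1OC` gives 30800 nM. Compound 3 `COc1ccc(/C(Cl)=C/C=C(\C#N)C(=O)c2c[nH]c3ccccc23)cc1OC` gives 44200 nM. The three numbers lie close together: the gap from compound 3 to compound 2 and the gap from compound 3 to compound 1 both fall within the usual scatter of repeated measurements, so none of the three can be set apart from the others on this read-out. Compound 3 is the only one of the three without a bromine on the bicyclic part of the core.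

Compound 4 `COc1ccc(/C(Cl)=C/C=C(\C#N)C(=O)c2c[nH]c3ccc(Br)cc23)cc1OC` is obtained from compound 3 by one change: bromo in place of hydrogen on an aromatic carbon. Within the data shown here, no directly comparable pair among the measured compounds isolates this change, since compound 1 and compound 2 differ from compound 3 in more than one place. What the measured numbers show is a set of values that do not separate from one another, and the two brominated compounds sit in the same band as compound 3. The step from compound 3 to compound 4 is therefore expected to stay within the scatter, with no clear direction, and is estimated as a 1.2-fold lower number from compound 3 to compound 4 (0.07 log units; within the scatter). Compound 4 is accordingly expected to give about 38000 nM in this assay, within a range from 13000 nM to 110000 nM.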

Compound 4, concentration for 50% growth inhibition: 31900 nM
Beside the measured number, compound 4's estimate is 1.2-fold (0.08 log units) above it, within the range that was stated.
By their numbers in this assay, from the lowest: compounds 2, 4, 3 and 1 (each within the scatter of the next, the first and the last beyond it).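

In this assay, among these compounds, the step of a 1.4-fold lower number from compound 3 to compound 4 (0.14 log units; within the scatter) is the first direct reading of bromo in place of hydrogen on this aromatic carbon of the fused system, and it lies within the scatter, so this one change cannot be told apart from no change on this read-out. With the bromo held constant, compound 4 also links the other two brominated compounds: hydrogen in place of methoxy gives a 1.0-fold higher number from compound 2 to compound 4 (0.02 log units; within the scatter), within the scatter, whereas methoxy in place of hydrogen gives a 2.5-fold lower number from compound 1 to compound 4 (0.40 log units; beyond the scatter), a modest step beyond the scatter and the only separable single change among these compounds. Nothing given here bears on why these steps have the sizes they do.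

The compounds shown leave open whether a different group on the same aromatic carbon, such as chloro, an amine or a carboxylic acid, would give a step beyond the scatter. They also leave open whether a longer chain, such as ethoxy in place of methoxy, would keep the separation seen between compound 1 and compound 4.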